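This account rests on a few compounds, and the source may have more. Where it says the series, first, only, none or still open, it means among the compounds named here.

Working notes on the series. Compound 3 `Cc1nnc(SCC(=O)N/N=c2/scc(-c3ccc(Cl)cc3)n2-c2ccccc2)s1` is the reference point for the next step. Among the measured compounds shown here, in an ADME assay on NIH3T3 cells (Mus musculus) for cytotoxicity, read by MTT assay, with a stated time of 24 h (on this read-out lower numbers stand for stronger inhibition and higher numbers for weaker inhibition), compound 3 gives 253 ug/mL, the highest of the three numbers measured so far. Compound 1 `Cc1nnc(SCC(=O)N/N=c2/scc(-c3ccccc3)n2-c2ccccc2)s1` is its nearest neighbour; in this assay compound 1 gives 197 ug/mL, and the step of a 1.3-fold higher number from compound 1 to compound 3 (0.11 log units; within the scatter) is therefore of no consequence. For the measured compounds named here, compound 2 `COc1ccc(-c2cs/c(=N/NC(=O)CSc3nnnn3-c3ccccc3)n2-c2ccccc2)cc1` in this assay gives 11.7 ug/mL, which is far below both other numbers; compound 2 differs from compound 1 and from compound 3 in more than one place, so no single step can be drawn from it.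

Compound 4 `O=C(CSc1nnnn1-c1ccccc1)N/N=c1/scc(-c2ccc(Cl)cc2)n1-c1ccccc1` is next to be measured. It differs from compound 3 by 1-phenyl-1H-tetrazol-5-yl in place of 5-methyl-1,3,4-thiadiazol-2-yl on a sulfur. Going by the values given here, no measured step isolates exactly this change. Among the compounds with values here, compound 2 is the only measured compound carrying the 1-phenyl-1H-tetrazol-5-yl group, and its value in this assay, 11.7 ug/mL, lies well below the numbers of compound 1 and compound 3, which both carry the 5-methyl-1,3,4-thiadiazol-2-yl group. On that basis the expected step of a 13-fold lower number from compound 3 to compound 4 (1.10 log units; beyond the scatter) is downward and beyond the scatter. The estimate for compound 4 in this assay is 20 ug/mL, with a range from 6 ug/mL to 70 ug/mL.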

Compound 4, half-maximal inhibitory concentration: 313 ug/mL
Beside the measured number, compound 4's estimate is 16-fold (1.19 log units) below it; measured number above the stated range.
By their numbers in this assay, from the lowest: compound 2; then compounds 1, 3 and 4 (each within the scatter of the next).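

Working from the 5-methyl-1,3,4-thiadiazol-2-yl group on a sulfur whose other neighbour is a saturated chain carbon, 1-phenyl-1H-tetrazol-5-yl can enter with the chloro group kept: in this assay this gives a 1.2-fold higher number from compound 3 to compound 4 (0.09 log units; within the scatter), so this exchange alone does not move the number out of the scatter. Among the compounds shown here, the low number of compound 2 therefore does not follow the 1-phenyl-1H-tetrazol-5-yl group by itself, and chloro in place of methoxy on an aromatic carbon gives a 27-fold higher number from compound 2 to compound 4 (1.43 log units; beyond the scatter), the only single-place step so far that lies beyond the scatter, while chloro in place of hydrogen on an aromatic carbon stayed within it in the 5-methyl-1,3,4-thiadiazol-2-yl compounds. Nothing measured here speaks to the reason for this large step.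

The compounds shown do not tell whether methoxy has the same effect with 5-methyl-1,3,4-thiadiazol-2-yl on the sulfur, or whether it needs 1-phenyl-1H-tetrazol-5-yl there. Nor do they tell whether a hydroxyl or an amine on that aromatic carbon would give a number near that of compound 2 at 11.7 ug/mL in this assay.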